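This account rests on a few compounds, and the source may have more. Where it says the series, first, only, none or still open, it means among the compounds named here.

Notes on the series, followed in a functional assay on HL-60 cells (Homo sapiens) for antiproliferative activity; a higher number here means a weaker inhibitor, a lower number a stronger inhibitor. Compound 1 `CCOC(=O)c1ccc(Oc2ccc(OC)cc2)cc1` gives > 20000 nM, which is a limit of the assay and not a number. Compound 2 `CCOC(=O)c1ccc(Oc2ccc(OC)c(F)c2)cc1` gives a measured 3500 nM. Compound 3 `CCOC(=O)c1ccc(Oc2ccc(OC)cc2)cc1O` gives > 30000 nM, again a limit and not a number. Going by the values given here, compound 3 therefore has no measured potency from which to count, and of the three values only that of compound 2 is a number.

The next structure, compound 4 `CCOC(=O)c1ccc(Oc2ccc(OC)c(F)c2)cc1O`, differs from compound 3 by fluoro in place of hydrogen on an aromatic carbon. This is fluoro in place of hydrogen on an aromatic carbon, ortho to a methoxy group.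

Among the compounds with values here, two measured steps bear on it. Within the data shown here, the same replacement gave an at least 5.7-fold lower number from compound 1 to compound 2 (0.75 log units; beyond the scatter), beyond the scatter, and this is the only direct precedent. On these data alone, the hydroxy replacement gave a step that the two limits leave unreadable from compound 1 to compound 3, whose size cannot be read, so the effect of the hydroxy group on the fluoro gain remains unknown.

A gain of similar size is therefore expected, towards a lower number, though with wide uncertainty and some chance that compound 4 also reaches a limit. The expected step is an at least 5.0-fold lower number from compound 3 to compound 4 (0.69 log units; beyond the scatter). For compound 4 the estimated value is 6000 nM, with an expected range from 1500 nM to 25000 nM.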

Compound 4, half-maximal inhibitory concentration: > 30000 nM
Compound 4 ended at the assay's limit; the forecaster's own chance of this, stated with the estimate: 20%; at least 5.0-fold (0.69 log units) between middle value and limit.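

In this assay compound 4 gives > 30000 nM, which is a limit of the assay and not a number. The hydroxy replacement, so far without a readable size, now has a direction in the fluoro-bearing pair: it gives an at least 8.5-fold higher number from compound 2 to compound 4 (0.93 log units; beyond the scatter), so the measured potency of compound 2 does not survive hydroxy in place of hydrogen on an aromatic carbon. The fluoro step, the only change that had improved potency, gives no readable gain once the hydroxy group is present, and neither it nor the hydroxy step between the two compounds without fluoro can be read, because limits stand at their ends: the limit of > 30000 nM in this assay, at which 2 of the 4 values shown sit.

On these data alone, whether fluoro in this place still has any effect alongside the hydroxy group stays open, since any such effect would lie beyond the limit of the assay. Also open, as far as these compounds go, is whether the loss belongs to the hydroxy group itself or would follow other groups on that carbon, such as an amine or a second methoxy group, and whether a carboxylic acid in place of the ethyl ester would change the picture.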